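Adding Chloro to the Acetylsulfonamide Pyrazole Series

The compounds below may be only part of what the source reports. "The series", "measured", "known", "first", "only" and "open" are said of these compounds alone.

Measured compounds in a functional assay on cells (Melanoma cell, Homo sapiens) for cytotoxicity, read by sulforhodamine B assay, with a stated time of 48 h; a higher number here means a weaker inhibitor of growth, a lower number a stronger inhibitor of growth:
compound 1 `Oc1ccc(O)c(-c2cc(-c3ccc(Cl)cc3)nn2-c2ccccc2)c1`, 8790 nM
compound 2 `NS(=O)(=O)c1ccc(-n2nc(-c3ccc(Cl)cc3)cc2-c2cc(O)ccc2O)cc1`, 14600 nM
compound 3 `CC(=O)NS(=O)(=O)c1ccc(-n2nc(-c3ccccc3)cc2-c2cc(O)ccc2O)cc1`, 84800 nM

Compound 3 gives the highest number of the three. Its nearest neighbour on the numbers is compound 2, whose value lies well beyond the scatter below it, and compound 1 lies further still. Compound 1 and compound 2 share the chloro group and differ by a single change, a 1.7-fold higher number from compound 1 to compound 2 (0.22 log units; within the scatter). Compound 3 differs from compound 2 in two places at once, so only the two values can be set side by side, and the gap between them is beyond the scatter.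

Compound 4 `CC(=O)NS(=O)(=O)c1ccc(-n2nc(-c3ccc(Cl)cc3)cc2-c2cc(O)ccc2O)cc1` is the subject of the step from compound 3: chloro in place of hydrogen on an aromatic carbon. Going by the values given here, no measured pair isolates this change, so the only guidance is indirect: compound 4 becomes the acetylated relative of compound 2, and compound 2 sits far below compound 3. The step is therefore expected to lower the number, a 2.4-fold lower number from compound 3 to compound 4 (0.38 log units; beyond the scatter), though with wide uncertainty. Compound 4 is estimated at 35000 nM, within a range from 12000 nM to 90000 nM.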

Compound 4, concentration for 50% growth inhibition: 36200 nM
Estimate against measurement, compound 4: 1.0-fold (0.01 log units) below, and the stated range covers the measured number.
By their numbers in this assay, from the lowest: compounds 1 and 2 (each within the scatter of the next); then compound 4; then compound 3.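

In this assay, going by these compounds alone, the change from phenyl to 4-chlorophenyl gives a 2.3-fold lower number from compound 3 to compound 4 (0.37 log units; beyond the scatter) in the only pair that isolates it, so chloro at this place on the ring moves the number modestly downward when the sulfonamide nitrogen carries acetyl. Within the data shown here, compound 4 also completes a pair with compound 2 and isolates the acetyl group for the first time, with a 2.5-fold higher number from compound 2 to compound 4 (0.39 log units; beyond the scatter) on the chloro background, a step in the opposite direction from the chloro step and of similar size. The whole acetylsulfamoyl group, set against hydrogen on the aromatic carbon, gives a 4.1-fold higher number from compound 1 to compound 4 (0.61 log units; beyond the scatter) as a step beyond the scatter, whereas the sulfamoyl group alone stayed within it, as a 1.7-fold higher number from compound 1 to compound 2 (0.22 log units; within the scatter) shows.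

No evidence at hand explains either the chloro step or the acetyl step.

On these data alone, whether chloro acts the same way without the acetyl group stays open, and a single pair cannot show whether fluoro, methoxy or a second chloro at this place would move the number further. The compounds shown also leave open what a longer acyl chain or a carboxylic acid would do in place of the acetyl group on the sulfonamide nitrogen.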